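Changing the Group on a Sulfonyl Sulfur

The source may report more compounds than this note shows. Statements on the series, on what has been measured and on what is new or still open speak of the compounds shown alone.

In a functional assay on L1210 cells (Mus musculus) for inhibition (a lower number here means a stronger inhibitor, a higher number a weaker inhibitor), compound 3 `C#CCN(Cc1ccc2nc(C)nc(O)c2c1)c1ccc(S(=O)(=O)C(F)(F)F)cc1` gives 2750 nM, while compound 2 `C#CCN(Cc1ccc2nc(C)nc(O)c2c1)c1ccc(S(N)(=O)=O)cc1` gives 20000 nM. Compound 3 therefore has the lower of these two numbers. Compound 1 `C#CCN(Cc1ccc2nc(C)nc(O)c2c1)c1ccc(Cl)cc1` reads > 4000 nM, which is a limit.

The unmeasured compound 4 `C#CCN(Cc1ccc2nc(C)nc(O)c2c1)c1ccc(S(=O)(=O)N2CCNCC2)cc1` carries piperazin-1-yl in place of trifluoromethyl on a sulfonyl sulfur. The nearest guide is a 7.3-fold lower number from compound 2 to compound 3 (0.86 log units; beyond the scatter), where trifluoromethyl replaced amino on that same sulfur. The other step, an at least 1.4-fold lower number from compound 1 to compound 3 (0.16 log units; that floor lies within the scatter), tells little. Compound 4 also has nitrogen on this sulfur, so a move towards compound 2 at 20000 nM is expected. The expected step in this assay is a 3.3-fold higher number from compound 3 to compound 4 (0.51 log units; beyond the scatter). For compound 4 the estimate is 9000 nM, with an expected range of 2500 nM to 30000 nM.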

Compound 4, half-maximal inhibitory concentration: > 50000 nM
Compound 4 was reported as a limit; the forecaster's own chance of this, stated with the estimate: 25%; middle value at least 5.5-fold (0.74 log units) from the limit.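

In this assay, compound 4 stands only as a limit: the limit of > 50000 nM in this assay, at which 1 of the 4 values shown sits. Piperazin-1-yl on the sulfonyl sulfur gives an at least 18-fold higher number from compound 3 to compound 4 (1.25 log units; beyond the scatter) and an at least 2.5-fold higher number from compound 2 to compound 4 (0.39 log units; beyond the scatter), so a nitrogen on this sulfur does not fix the number: the two nitrogen groups, amino and piperazin-1-yl, are themselves separated by a step beyond the scatter. The step from compound 1 to compound 4 cannot be read. The compounds shown leave open where a methyl group or a dimethylamino group on this sulfur would fall, and whether either would come closer to compound 3 or to compound 4.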